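The source may hold more compounds than are shown below. What is called first, only, known or untested is meant among the compounds shown, and "the series" means these compounds.

Measured compounds:

compound 1 `C=CCn1ncc2c(C)nc(C)n2c1=O`: 73000 nM
compound 2 `C=CCn1ncc2c(C)nc(CCC)n2c1=O`: 40000 nM
compound 3 `CCCc1nc(C)c2c(C)nnc(SC)n12`: > 48000 nM

All three were tested in a functional assay for inhibition, with Homo sapiens as the target; on this read-out lower numbers stand for stronger inhibition and higher numbers for weaker inhibition. Compound 1 gives 73000 nM in this assay, and compound 2 gives 40000 nM. The two differ by ethyl in place of hydrogen on a saturated chain carbon bound to an aromatic carbon, and the step of a 1.8-fold lower number from compound 1 to compound 2 (0.26 log units; within the scatter), so the two numbers are not told apart here. For compound 3 the assay reports only a limit, > 48000 nM, and no number; it sits at the limit of > 48000 nM in this assay, at which 1 of the 3 values shown sits. The difference between the core of compound 1 and the core of compound 3 is not broken down here.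

Compound 4 `CCCc1nnc(SC)n2c(CCC)nc(C)c12` has not yet been measured. It differs from compound 3 by ethyl in place of hydrogen on a saturated chain carbon bound to an aromatic carbon, the same change, at the same place, as that from compound 1 to compound 2. Since the step of a 1.8-fold lower number from compound 1 to compound 2 (0.26 log units; within the scatter) was within the scatter, the step for compound 4 is expected to be small as well, a step that the limit leaves unreadable from compound 3 to compound 4, and with compound 3 resting only on a limit, compound 4 may well return a limit too. Compound 4 is therefore estimated at 50000 nM, in a range from 15000 nM to 150000 nM.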

Compound 4, half-maximal inhibitory concentration: > 48000 nM
Compound 4: only a limit was reported (the forecaster's own chance of this, stated with the estimate: 60%); the middle value is on the limit's open side.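

Compound 3 and compound 4 each return only a limit in this assay, so no step from one to the other can be read: the limit of > 48000 nM in this assay, at which 2 of the 4 values shown sit.

The compounds shown leave open where compound 3 and compound 4 truly lie, and whether ethyl in place of hydrogen changes anything on the core of compound 3.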